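Removing the Methyl Group from Compound 1

The source may report more compounds than this note shows. Statements on the series, on what has been measured and on what is new or still open speak of the compounds shown alone.

Four compounds are compared in a functional assay, read by spectrophotometry, with a stated time of 30 min; on this read-out lower numbers stand for stronger inhibition and higher numbers for weaker inhibition. For the measured compounds named here, compound 1 `Cc1ccc2[nH]c(=O)c(/C=N/c3ccccc3O)cc2c1` gives 26200 nM in this assay, the lowest of the three numbers measured so far. Compound 2 `Cc1ccc2[nH]c(=O)c(/C=N/Nc3ccc([N+](=O)[O-])cc3)cc2c1` gives 109000 nM in this assay, and compound 3 `O=c1[nH]c2ccccc2cc1/C=N/Nc1ccc([N+](=O)[O-])cc1` gives 170000 nM in this assay. The difference between the core of compound 1 and the core of compound 2 is not broken down here.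

Compound 2 and compound 3 differ in one place only:
hydrogen in place of methyl on an aromatic carbon
This change produced a 1.6-fold higher number from compound 2 to compound 3 (0.19 log units; within the scatter), so the two compounds cannot be ordered against each other.

Compound 4 `O=c1[nH]c2ccccc2cc1/C=N/c1ccccc1O` has not yet been measured in this assay. It differs from compound 1 by the same change, at the same place:
hydrogen in place of methyl on an aromatic carbon

Since this change occurs only twice among the compounds shown, the one measured example is the sole guide. For compound 4 the expected step is a 1.5-fold higher number from compound 1 to compound 4 (0.18 log units; within the scatter), because the same change earlier gave a 1.6-fold higher number from compound 2 to compound 3 (0.19 log units; within the scatter). Compound 4 is therefore estimated at 40000 nM in this assay, expected to fall between 15000 nM and 110000 nM. A number beyond the scatter would show that the methyl group counts for more on the core of compound 1 than it did on the core of compound 2.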

Compound 4, half-maximal inhibitory concentration: 22800 nM
Beside the measured number, compound 4's estimate is 1.8-fold (0.24 log units) above it; measured number inside the range.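

In this assay, taking the methyl group off the aromatic carbon gave a 1.1-fold lower number from compound 1 to compound 4 (0.06 log units; within the scatter), so the two compounds cannot be ordered against each other, just as compound 2 and compound 3 could not. Set side by side, the two steps do not differ, and on the evidence of these two pairs the change carries from one core to the other without a detectable difference: the same change on two cores in this assay, a 1.6-fold higher number (0.19 log units; within the scatter) from compound 2 to compound 3 and a 1.1-fold lower number (0.06 log units; within the scatter) from compound 1 to compound 4, 1.8-fold (0.25 log units) apart, within the scatter of two such steps. This shows that, on both cores, replacing methyl with hydrogen left the number within the usual scatter, but it does not show that the methyl group has no effect at all, that the two steps truly run in different directions, or that the same would hold on any core beyond these two.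

The compounds shown leave open whether another group at this place, such as an amine, a carboxylic acid or a longer chain, would move the number beyond the scatter on either core. Also open is which of the several differences between compound 1 and compound 2 accounts for the gap between their numbers, and no pair shown isolates any one of them.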